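The compounds below may be only part of what the source reports. "The series", "measured", "known", "first", "only" and "open" are said of these compounds alone.

Measured compounds:
Compound 1 `Nc1cc(-c2ccccc2)nc2ccc(NC(=O)/C=C/c3ccc(C(F)(F)F)cc3)cc12` gives 18.5 nM in an assay on isolated protein for displacement of a labelled ligand from melanin-concentrating hormone receptor 1 (Homo sapiens); on this read-out lower numbers stand for stronger inhibition and higher numbers for weaker inhibition.
Compound 2 `CCC(C)c1cc(N)c2cc(NC(=O)/C=C/c3ccc(C(F)(F)F)cc3)ccc2n1` gives 0.3 nM in this assay.
Compound 3 `CCCc1cc(N)c2cc(NC(=O)c3ccc(-c4ccc(C(F)(F)F)cc4)cc3)ccc2n1` gives 4.5 nM in this assay.

Compound 2 stands at the lowest number of the three: compound 3 sits well above it and compound 1 further still, both gaps beyond the scatter. Within the data shown here, the single one-point step measured so far, a 62-fold lower number from compound 1 to compound 2 (1.79 log units; beyond the scatter), shows that the group on this aromatic carbon of the shared core matters greatly. Compound 4 `Nc1cc(C2CCC2)nc2ccc(NC(=O)/C=C/c3ccc(C(F)(F)F)cc3)cc12` alters the same position: cyclobutyl in place of sec-butyl on an aromatic carbon. Among the measured compounds shown here, only the step from compound 1 to compound 2 bears on this, and it compares a phenyl with a sec-butyl, not a chain with a small ring of like heavy-atom count. With the entering and leaving groups matched in size and lacking donors and acceptors alike, no step beyond the scatter is expected, with a slight lean toward a higher number as the less certain side. Compound 4 is therefore expected at 0.6 nM, estimated between 0.15 nM and 2.5 nM. The expected step is a 2.0-fold higher number from compound 2 to compound 4 (0.30 log units; within the scatter).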

Compound 4, half-maximal inhibitory concentration: 2 nM
For compound 4 the middle estimate is 3.3-fold (0.52 log units) below the measured one, within the range that was stated.
By their numbers in this assay, from the lowest: compound 2; then compound 4; then compound 3; then compound 1.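

At this carbon next to the ring nitrogen, sec-butyl and cyclobutyl are not interchangeable in this assay, although both have 4 heavy atoms and neither has a hydrogen-bond donor or acceptor: the change gives a 6.7-fold higher number from compound 2 to compound 4 (0.82 log units; beyond the scatter) on the same cinnamide-free comparison of the shared core. Cyclobutyl still retains part of the gain over phenyl, with a 9.3-fold lower number from compound 1 to compound 4 (0.97 log units; beyond the scatter) at this position, so the three groups rank sec-butyl, then cyclobutyl, then phenyl. No measurement available here accounts for the gap between the open chain and the ring.

As far as these compounds go, it remains open whether the gap follows from ring closure itself or from the particular ring, which cyclopropyl or cyclopentyl at this carbon would address. From the compounds shown here alone, how an isopropyl or tert-butyl group, or a chain carrying an amine, would compare on this core also remains open.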